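Hydroxyphenyl positional swap in two related pairs

A few compounds are considered here, and "the series" means these few. Any claim that something is new, unique, unknown or untested is made for them only; others in the source may bear on it.

Compound 1 `O=C(/C=C/c1cccc(O)c1)CC(=O)/C=C/c1cccc(O)c1O` and compound 2 `O=C(/C=C/c1ccc(O)cc1)CC(=O)/C=C/c1cccc(O)c1O` share one core; compound 3 `O=C(/C=C/c1cccc(O)c1)/C=C/c1ccc(O)c(O)c1` and compound 4 `O=C(/C=C/c1ccc(O)cc1)/C=C/c1ccc(O)c(O)c1` share another. How the two cores differ is not broken down here. In an ADME assay on PC-12 cells (Rattus norvegicus) for cytotoxicity, read by WST assay, with a stated time of 24 h (on this read-out higher numbers stand for lower toxicity in this test and lower numbers for higher toxicity in this test), compound 1 gives 38000 nM. Compound 2 carries 4-hydroxyphenyl in place of 3-hydroxyphenyl on a double-bonded chain carbon bound to a double-bonded chain carbon and gives 8500 nM in this assay, so the change made a 4.5-fold lower number from compound 1 to compound 2 (0.65 log units; beyond the scatter). In this assay compound 3 gives only a limit, > 100000 nM. That value sits at the limit of > 100000 nM in this assay, at which 1 of the 3 values shown sits. Compound 4 has not yet been measured in this assay; it differs from compound 3 by 4-hydroxyphenyl in place of 3-hydroxyphenyl on a double-bonded chain carbon bound to a double-bonded chain carbon, the same change as between compound 1 and compound 2, made in the same place. For compound 4 a step of an at least 1.6-fold lower number from compound 3 to compound 4 (0.22 log units; that floor lies within the scatter) is expected in this assay. This rests on the same change having given a 4.5-fold lower number from compound 1 to compound 2 (0.65 log units; beyond the scatter). The value of compound 3 is a limit, not a number. The expected range is wide and a further limit is possible. Compound 4 is estimated at 60000 nM, with a range from 20000 nM to 200000 nM.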

Compound 4, half-maximal cytotoxic concentration: 12000 nM
Compound 4: the middle estimate sits 5.0-fold (0.70 log units) above what was measured, outside the stated range (below it).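

In this assay the change to 4-hydroxyphenyl on a double-bonded chain carbon bound to a double-bonded chain carbon gives an at least 8.3-fold lower number from compound 3 to compound 4 (0.92 log units; beyond the scatter), the same direction as on the first core. The direction therefore carries over in these two pairs, but no shared size can be claimed, and two pairs make no rule for the whole series: the same change on two cores in this assay, a 4.5-fold lower number (0.65 log units; beyond the scatter) from compound 1 to compound 2 and an at least 8.3-fold lower number (0.92 log units; beyond the scatter) from compound 3 to compound 4; the limit leaves it open whether they differ Compound 3 stands at a limit and not at a number: the limit of > 100000 nM in this assay, at which 1 of the 4 values shown sits.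

All the aromatic rings shown carry only hydroxyl groups, so it remains open whether the step would survive if an amine or a carboxylic acid stood in place of the hydroxyl group of the 4-hydroxyphenyl. As far as these compounds go, it also remains open whether the same swap would lower the number on a core with a longer chain, or on a core where neither partner of the pair sits at a limit.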